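A few compounds are considered here, and "the series" means these few. Any claim that something is new, unique, unknown or untested is made for them only; others in the source may bear on it.

Measured compounds:
- Compound 1, `O=C1CCc2ccc(OCc3cccc(Br)c3)cc2N1`: 2.9 nM
- Compound 2, `O=C1CCc2cc(OCc3cccc(Cl)c3)ccc2N1`: 620 nM

Of the compounds shown here, two have been measured in an assay on isolated protein for inhibition of Amine oxidase [flavin-containing] B (Homo sapiens), read by fluorescence and spectrophotometry, with a stated time of 20 min; on this read-out higher numbers stand for weaker inhibition and lower numbers for stronger inhibition. Compound 1, with structure `O=C1CCc2ccc(OCc3cccc(Br)c3)cc2N1`, gives 2.9 nM. Compound 2, with structure `O=C1CCc2cc(OCc3cccc(Cl)c3)ccc2N1`, gives 620 nM. Of the two numbers, compound 2 stands at the higher one. Going by the values given here, the gap between compound 2 and compound 1 lies well beyond the usual scatter, and the two compounds differ in more than one place, so no single step between them is recorded.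

Compound 3, with structure `O=C1CCc2cc(OCc3cccc(Br)c3)ccc2N1`, has not yet been measured. It differs from compound 2 in one place: bromo in place of chloro on an aromatic carbon. Among the compounds with values here, no step between measured compounds isolates this exchange, so its effect in this assay is unknown. The closest guide is that the exchange of one halogen for another of the same kind of group, at the same position, is a small change; a small downward move, or none beyond the scatter, is the expectation.

For compound 3, the estimated value in this assay is 400 nM, within a range of 150 nM to 1500 nM. The expected step is a 1.6-fold lower number from compound 2 to compound 3 (0.19 log units; within the scatter).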

Compound 3, half-maximal inhibitory concentration: 86 nM
The estimate for compound 3 lay 4.7-fold (0.67 log units) above the measured number; measured number outside the range, below it.
By their numbers in this assay, from the lowest: compound 1; then compound 3; then compound 2.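

In this assay this position proves sensitive to which halogen it carries: bromo in place of chloro on an aromatic carbon, meta to a large group, gives a 7.2-fold lower number from compound 2 to compound 3 (0.86 log units; beyond the scatter) and this lies beyond the scatter, even though one heavy atom simply replaces one heavy atom and no ring, hydrogen-bond donor, hydrogen-bond acceptor or net charge enters or leaves. The earlier compounds shown here could not show this, since compound 1 and compound 2 differ in more than one place and so isolate no single change. Nothing measured here accounts for the size of this step.

The compounds shown leave open whether the move continues or reverses with other groups at this position, such as fluoro, iodo, methyl or a nitrile. They also leave open whether the same exchange of chloro and bromo would give a step of similar size on the core of compound 1, since only one such pair is shown.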